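Swapping a Methyl for 4-Ethylphenyl on the Sulfonyl Sulfur

The source may report more compounds than this note shows. Statements on the series, on what has been measured and on what is new or still open speak of the compounds shown alone.

Compound 1 `CS(=O)(=O)Nc1ccc(-c2nc3cc(NS(=O)(=O)c4ccc(Cl)s4)ccc3o2)cc1` gives 43000 nM in an assay on cells for inhibition of HSP60/HSP10 (Homo sapiens), with a stated time of 60 min; on this read-out higher numbers stand for weaker inhibition and lower numbers for stronger inhibition. Compound 2 `CS(=O)(=O)Nc1ccc(-c2nc3ccccc3o2)cc1` reaches only a limit of this assay, > 100000 nM. Compound 3 `COc1cccc(S(=O)(=O)Nc2ccc3oc(-c4ccccc4)nc3c2)c1` likewise reaches only a limit, > 100000 nM.

Compound 2 thus sits at the weak end of what this assay can report, a limit at which (the limit of > 100000 nM in this assay, at which 2 of the 3 values shown sit). For the measured compounds named here, the one measured step that touches it, an at least 2.3-fold higher number from compound 1 to compound 2 (0.36 log units; beyond the scatter), removed an arylsulfonamide from the shared core and left a compound too weak to give a number. Compound 4 `CCc1ccc(S(=O)(=O)Nc2ccc(-c3nc4ccccc4o3)cc2)cc1` differs from compound 2 at a different place: 4-ethylphenyl in place of methyl on a sulfonyl sulfur. Going by the values given here, no measured step changes the sulfonyl substituent itself, so the step to compound 4 has no direct precedent; compound 3, which carries an arylsulfonamide, also reaches only a limit. For compound 4 a step of an at least 1.2-fold lower number from compound 2 to compound 4 (0.09 log units; that floor lies within the scatter) is expected, which is to say no clear gain beyond the scatter. The estimate for compound 4 in this assay is therefore 80000 nM, within a range of 20000 nM to 300000 nM.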

Compound 4, half-maximal inhibitory concentration: > 100000 nM
Compound 4: a limit, no number; the forecaster's own chance of this, stated with the estimate: 55%; middle value at least 1.2-fold (0.09 log units) from the limit.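

For the compounds shown here, compound 2 and compound 4 both reach only a limit in this assay, so no step between them can be read: the limit of > 100000 nM in this assay, at which 3 of the 4 values shown sit.

The compounds shown leave open whether 4-ethylphenyl in place of methyl on a sulfonyl sulfur changes inhibition at all.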